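A Trifluoromethoxy Group Added to an Inactive Sulfonamide Series

The source may report more compounds than this note shows. Statements on the series, on what has been measured and on what is new or still open speak of the compounds shown alone.

Compound 1 (`O=S(=O)(NC1=NCCN1C(=S)SN1CCn2c1nsc2=S)c1ccccc1`) is the parent of this small set. In a functional assay on KYSE-510 cells (Homo sapiens) for antiproliferative activity, read by crystal violet staining, with a stated time of 96 h (a higher number here means a weaker inhibitor of growth, a lower number a stronger inhibitor of growth), compound 1 reaches only the assay limit of >= 20000 nM, so no number is known for it, merely that it is a limit. Compound 2 (`Cc1cc(C)c(S(=O)(=O)NC2=NCCN2C(=S)SN2CCn3c2nsc3=S)c(C)c1`) carries 2,4,6-trimethylphenyl on the sulfonyl sulfur, and in this assay compound 2 likewise sits at the limit of >= 20000 nM. Compound 3 (`COc1ccc(OC)c(S(=O)(=O)NC2=NCCN2C(=S)SN2CCn3c2nsc3=S)c1`) carries 2,5-dimethoxyphenyl there, and in this assay compound 3 also returns the limit >= 20000 nM. Because all three values sit at the limit of >= 20000 nM in this assay, at which 3 of the 3 values shown sit, the steps a step that the two limits leave unreadable from compound 1 to compound 2, a step that the two limits leave unreadable from compound 1 to compound 3 and a step that the two limits leave unreadable from compound 2 to compound 3 cannot be read in either direction or size. Compound 4 (`O=S(=O)(NC1=NCCN1C(=S)SN1CCn2c1nsc2=S)c1ccc(OC(F)(F)F)cc1`) differs from compound 1 by trifluoromethoxy in place of hydrogen on an aromatic carbon. Among the measured compounds shown here, none of the measured steps can say how large a move a change on this ring produces, since each of them starts and ends at the limit, and compound 2 and compound 3 show that two quite different substitution patterns on that ring leave the readout unchanged. The change to compound 4 is therefore expected to give a step of a number no higher from compound 1 to compound 4 (the limit leaves the size open) in this assay, most likely ending once more at the limit. Compound 4 is thus estimated at 20000 nM, with a range from 8000 nM to 50000 nM.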

Compound 4, concentration for 50% growth inhibition: >= 20000 nM
Compound 4 was reported as a limit; the forecaster's own chance of this, stated with the estimate: 80%; the middle value sits exactly at the limit.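

No new step can be read: compound 4 and compound 1 both stand only at a limit in this assay, so the change between them has neither a readable size nor a direction: the limit of >= 20000 nM in this assay, at which 4 of the 4 values shown sit.

The compounds shown leave open whether any change, on the aromatic ring or on the shared core, would give a real number in this assay.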